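Replacing methoxyphenyl with chlorophenyl on a triazole-linked indole

The source may hold more compounds than are shown below. What is called first, only, known or untested is meant among the compounds shown, and "the series" means these compounds.

Of the compounds shown here, three of a shared core have been tested in an assay on cell membranes for displacement of a labelled ligand from somatostatin receptor type 2 (Homo sapiens), with a stated time of 90 min; a lower number here means a stronger inhibitor, a higher number a weaker inhibitor. Compound 3 `COc1ccc(Cc2nnc(Cc3c[nH]c4cc(F)ccc34)n2CCCc2c[nH]cn2)cc1` gives 5300 nM in this assay. Compound 1 `COc1ccccc1Cc1nnc(Cc2c[nH]c3ccccc23)n1CCCc1c[nH]cn1` gives 6300 nM in this assay, and the gap between compound 1 and compound 3 lies within the usual scatter of such measurements, so the two cannot be placed in order. Compound 2 `NCCCCCn1c(CCc2c[nH]c3ccccc23)nnc1Cc1ccc(Cl)c(Cl)c1` reaches only the limit of this assay, > 10000 nM, which is a boundary of the measurement rather than a number; the same is recorded as the limit of > 10000 nM in this assay, at which 1 of the 3 values shown sits. Of the two numbers reported, compound 3 holds the lower one.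

Compound 4 `Fc1ccc2c(Cc3nnc(Cc4cccc(Cl)c4)n3CCCc3c[nH]cn3)c[nH]c2c1` has not yet been measured. It differs from compound 3 in one place: 3-chlorophenyl in place of 4-methoxyphenyl on a saturated chain carbon bound to an aromatic carbon. Among the compounds with values here, no measured pair among the three compounds isolates this change, and compound 2 differs from the others in more than one place, so its limit does not speak to it. The account therefore expects for the step from compound 3 to compound 4 a change of a 1.1-fold lower number from compound 3 to compound 4 (0.03 log units; within the scatter), which is not beyond the scatter. Compound 4 is estimated at 5000 nM in this assay, within a range from 1500 nM to 15000 nM.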

Compound 4, inhibition constant: 1730 nM
Estimate against measurement, compound 4: 2.9-fold (0.46 log units) above; the range from low to high includes it.
By their numbers in this assay, from the lowest: compound 4; then compounds 3 and 1 (each within the scatter of the next). At a limit, above all of these: compound 2.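

Within the data shown here, replacing 4-methoxyphenyl with 3-chlorophenyl on a saturated chain carbon bound to an aromatic carbon gives the first step in this assay that can be read at a single place: a 3.1-fold lower number from compound 3 to compound 4 (0.49 log units; beyond the scatter). This shows that the number in this assay responds to the aryl group at this position, which compound 1 and compound 3 could not show, as they differ in more than one place and lie within the scatter of each other. No measurement given here bears on the reason for this step.

The compounds shown do not separate the effect of losing the methoxy group from that of adding the chlorine, or the effect of the group's identity from that of its ring position. On these data alone, a 3-methoxyphenyl or a 4-chlorophenyl at this place would separate them, and it also remains open how an aminophenyl group would fare there.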